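This account rests on a few compounds, and the source may have more. Where it says the series, first, only, none or still open, it means among the compounds named here.

Compound 1 `CC(C)(C)Sc1c(CC(C)(C)C(=O)O)n(Cc2ccc(Cl)cc2)c2ccc(OCc3ccc4cc(F)ccc4n3)cc12` gives 880 nM in a functional assay (blood) for inhibition, with Homo sapiens as the target; on this read-out lower numbers stand for stronger inhibition and higher numbers for weaker inhibition.
Compound 2 `Cc1nc2ccc(COc3ccc4c(c3)c(SC(C)(C)C)c(CC(C)(C)C(=O)O)n4Cc3ccc(Cl)cc3)cc2s1` reaches only the limit > 3000 nM in this assay.
Compound 3 `CC(C)(C)Sc1c(CC(C)(C)C(=O)O)n(Cc2ccc(Cl)cc2)c2ccc(OCc3cccnc3)cc12` likewise reaches only the limit > 3000 nM.

Among the three, compound 1 holds the only real number; the other two values are limits, as the limit of > 3000 nM in this assay, at which 2 of the 3 values shown sit, records. Compound 4 `C[C@H](COc1ccc2c(c1)c(SC(C)(C)C)c(CC(C)(C)C(=O)O)n2Cc1ccc(Cl)cc1)c1ccccn1` is not yet measured and differs from compound 1 in one place: 1-(pyridin-2-yl)ethyl in place of 6-fluoroquinolin-2-yl on a saturated chain carbon bound to an oxygen on an aromatic ring. Among the compounds with values here, two measured steps bear on this change. Exchanging the same group gave an at least 3.4-fold higher number from compound 1 to compound 2 (0.53 log units; beyond the scatter) and an at least 3.4-fold higher number from compound 1 to compound 3 (0.53 log units; beyond the scatter), both weakening. Since the entering group of compound 4 carries a pyridinyl ring as compound 3 does, a weakening of similar size is expected, a 4.5-fold higher number from compound 1 to compound 4 (0.66 log units; beyond the scatter). Compound 4 is therefore estimated at 4000 nM, between 1500 nM and 12000 nM, with a fair chance that only a limit is reported.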

Compound 4, half-maximal inhibitory concentration: 470 nM
Compound 4: the middle estimate sits 8.5-fold (0.93 log units) above what was measured, and the stated range ends above it.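

Exchanging 6-fluoroquinolin-2-yl for 1-(pyridin-2-yl)ethyl gives a 1.9-fold lower number from compound 1 to compound 4 (0.27 log units; within the scatter), so a group with a single aromatic ring can serve at this position. In place of pyridin-3-yl the same group gives an at least 6.3-fold lower number from compound 3 to compound 4 (0.80 log units; beyond the scatter), and in place of 2-methyl-1,3-benzothiazol-6-yl it gives an at least 6.3-fold lower number from compound 2 to compound 4 (0.80 log units; beyond the scatter). Both of these steps start from a limit, not a number: the limit of > 3000 nM in this assay, at which 2 of the 4 values shown sit.

As far as these compounds go, it stays open whether the ethyl chain, its defined stereocentre or the pyridin-2-yl attachment accounts for the difference from compound 3. From the compounds shown here alone, how an amine or a carboxylic acid on the pyridinyl ring would read in this assay also stays open.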